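Three chalcones at the assay limit, and a chlorohydroxy analogue

A few compounds are considered here, and "the series" means these few. Any claim that something is new, unique, unknown or untested is made for them only; others in the source may bear on it.

Compound 1 `COc1ccc(C(=O)/C=C/c2ccc(F)cc2)c2c1C=CC(C)(C)O2` is measured in a functional assay on HCT-116 cells (Homo sapiens) for antiproliferative activity, read by MTT assay, with a stated time of 24 h; a higher number here means a weaker inhibitor, a lower number a stronger inhibitor. In this assay compound 1 gives only a limit, > 10000 nM, and not a number. Compound 2 `COc1ccc(C(=O)/C=C/c2cccc3ccccc23)c2c1C=CC(C)(C)O2` likewise gives only a limit in this assay, > 10000 nM. Compound 3 `COc1cc(/C=C/C(=O)c2ccc(OC)c3c2OC(C)(C)C=C3)cc(OC)c1O` also gives only a limit in this assay, > 10000 nM. Within the data shown here, compound 1 therefore stands at the limit of > 10000 nM in this assay, at which 3 of the 3 values shown sit, so no ranking among compounds 1, 2 and 3 can be drawn, and no step between measured compounds is available.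

Compound 4 `COc1ccc(C(=O)/C=C/c2cc(Cl)ccc2O)c2c1C=CC(C)(C)O2` has not yet been measured in this assay. It differs from compound 1 in one place (5-chloro-2-hydroxyphenyl in place of 4-fluorophenyl on a double-bonded chain carbon bound to a double-bonded chain carbon). With every measured compound sitting at the limit, there is no basis for expecting this change to move the value beyond the scatter in either direction, and the step that the limit leaves unreadable from compound 1 to compound 4 is expected to be small. Compound 4 is expected to give about 12000 nM in this assay, within a range from 3000 nM to 50000 nM, with a substantial chance that only a limit is reported.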

Compound 4, half-maximal inhibitory concentration: 5240 nM
Estimate against measurement, compound 4: 2.3-fold (0.36 log units) above, and the stated range covers the measured number.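

In this assay compound 4 gives 5240 nM, the only number among the compounds shown, so a change on a double-bonded chain carbon bound to a double-bonded chain carbon can bring a value into the readable range. Placing 5-chloro-2-hydroxyphenyl there instead of 4-fluorophenyl gives an at least 1.9-fold lower number from compound 1 to compound 4 (0.28 log units; that floor lies within the scatter). The true size of this step remains unknown, because compound 1 gives a limit and not a number: the limit of > 10000 nM in this assay, at which 3 of the 4 values shown sit.

As far as these compounds go, the change brings chlorine and hydroxyl together, and which of the two carries the step stays open. Also open, from the compounds shown here alone, is how the value would respond to an amine or a carboxylic acid in place of the hydroxyl on the 5-chloro-2-hydroxyphenyl group.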